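A few compounds are considered here, and "the series" means these few. Any claim that something is new, unique, unknown or untested is made for them only; others in the source may bear on it.

Measured compounds in a functional assay on PC-9 cells (Homo sapiens) for inhibition, read by MTT assay, with a stated time of 72 h; on this read-out higher numbers stand for weaker inhibition and lower numbers for stronger inhibition:
- compound 1 `Cc1cc(Nc2cc(-c3ccccc3)[nH]n2)n2ncnc2n1`: > 50000 nM, a limit of the assay rather than a number
- compound 2 `Cc1cc(Nc2cc(-c3ccccc3)[nH]n2)n2nc(SCc3ccc(Cl)cc3)nc2n1`: 6710 nM
- compound 3 `Cc1cc(Nc2cc(-c3ccccc3)[nH]n2)n2nc(SCCc3ccccc3)nc2n1`: 4930 nM

Compound 1 stands only at the limit of > 50000 nM in this assay, at which 1 of the 3 values shown sits; where its true number lies beyond that limit is not known. The two substituted analogues are measured as numbers. The step of an at least 7.4-fold lower number from compound 1 to compound 2 (0.87 log units; beyond the scatter) and the step of an at least 10-fold lower number from compound 1 to compound 3 (1.00 log units; beyond the scatter) both run the same way, each carrying a sulfanyl-linked aryl-bearing chain onto the same aromatic carbon of the shared core, and each read against a limit, so each is a lower bound on the true drop. Between the two substituted compounds the step of a 1.4-fold lower number from compound 2 to compound 3 (0.13 log units; within the scatter) is within the scatter, so the two chains cannot be told apart on these numbers.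

Compound 4 `Cc1cc(Nc2cc(-c3ccccc3)[nH]n2)n2nc(SCC3CCCCC3)nc2n1` differs from compound 1 by (cyclohexylmethyl)sulfanyl in place of hydrogen on an aromatic carbon. Both measured steps bear on this change: a chain of comparable length through sulfur at the same place, here ending in a saturated ring instead of an aromatic one. By analogy a step in this assay of at least the size seen for compound 2 and compound 3 is expected, toward lower numbers, though only the lower bound is anchored. Compound 4 is expected to give 5500 nM, with a range from 1800 nM to 18000 nM. The estimate implies a step of an at least 9.0-fold lower number from compound 1 to compound 4 (0.95 log units; beyond the scatter).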

Compound 4, half-maximal inhibitory concentration: > 50000 nM
Compound 4: no number, only a limit; the forecaster's own chance of this, stated with the estimate: 10%; at least 9.0-fold (0.95 log units) between middle value and limit.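

In this assay compound 4 gives > 50000 nM, a limit of the assay and not a number, and its step from compound 1 cannot be read, as both compounds sit at that limit: the limit of > 50000 nM in this assay, at which 2 of the 4 values shown sit.

Adding a sulfanyl-linked chain at this aromatic carbon is therefore not enough in itself to bring the number down, since the change to a cyclohexyl end gives an at least 7.4-fold higher number from compound 2 to compound 4 (0.87 log units; beyond the scatter) and an at least 10-fold higher number from compound 3 to compound 4 (1.00 log units; beyond the scatter). Among the substituted compounds, measurable numbers so far go only with the aromatic chain ends of compound 2 and compound 3, and compound 4 goes against any reading that credits the sulfur-linked chain alone.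

Open, as far as these compounds go, is whether the aromatic ring itself matters or the chain length and ring end together, which a 2-cyclohexylethylsulfanyl chain or a pyridin-4-ylmethylsulfanyl chain at the same carbon would help separate. How far compound 1 and compound 4 each lie beyond the limit is also unknown, so the two cannot be ordered.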